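The source may hold more compounds than are shown below. What is called first, only, known or untested is meant among the compounds shown, and "the series" means these compounds.

Of the compounds shown here, two built on a shared core have so far been tested in a functional assay on Jurkat cells (Homo sapiens) for cytotoxicity, read by MTT assay, with a stated time of 24 h; a lower number here means that less compound is needed, a higher number that more compound is needed for the effect. Compound 1 `CCCCC#Cc1cc(C(=O)OCC)nc2ccc(OC)cc12` gives 15900 nM in this assay, and compound 2 `CCOC(=O)c1cc(C#Cc2ccccc2[N+](=O)[O-])c2cc(OC)ccc2n1` gives 54700 nM. Among these two numbers compound 2 stands highest, and compound 1 is its only neighbour; the single measured step so far is a 3.4-fold higher number from compound 1 to compound 2 (0.54 log units; beyond the scatter), a modest rise lying beyond the scatter. The next compound, compound 3 `CCOC(=O)c1cc(C#CCCO)c2cc(OC)ccc2n1`, differs from compound 2 in one place: 2-hydroxyethyl in place of 2-nitrophenyl on a triple-bonded carbon. Within the data shown here, no measured step matches this exact change. The step that bears on it most is the one already shown, in which butyl on the triple-bonded carbon was replaced by 2-nitrophenyl and the number rose. Compound 3 removes the 2-nitrophenyl again and brings in 2-hydroxyethyl, a chain rather than a ring, so the number is expected to move back toward that of compound 1, though not necessarily all the way, because compound 1 gives 15900 nM with butyl on the triple-bonded carbon and 2-hydroxyethyl is not butyl. The estimated step is a 2.2-fold lower number from compound 2 to compound 3 (0.34 log units; beyond the scatter). For compound 3 the expected value in this assay is 25000 nM, with a range from 9000 nM to 70000 nM.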

Compound 3, half-maximal effective concentration: 123000 nM
For compound 3 the middle estimate is 4.9-fold (0.69 log units) below the measured one; measured number above the stated range.
By their numbers in this assay, from the lowest: compound 1; then compound 2; then compound 3.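

Putting 2-hydroxyethyl on the triple-bonded carbon in place of the 2-nitrophenyl ring did not bring the number back toward that of compound 1: in this assay there is a 2.2-fold higher number from compound 2 to compound 3 (0.35 log units; beyond the scatter), so having a chain rather than a ring at this position does not by itself give a lower number. The two chains also differ sharply, since hydroxy in place of ethyl on a saturated chain carbon, two bonds along the chain from a triple-bonded carbon, gives a 7.7-fold higher number from compound 1 to compound 3 (0.89 log units; beyond the scatter), which makes this single change enough to take compound 3 past compound 2 to the highest number of the three. Nothing available explains this rise.

The compounds shown leave open whether the rise depends on the hydroxy group itself or on the shorter chain that carries it, which a longer chain bearing a hydroxy group, or an amine in place of the hydroxy, would help to separate. They also leave open how much of the step from butyl to 2-nitrophenyl belongs to the ring and how much to its nitro group, a question that an unsubstituted phenyl group would address.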